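A few compounds are considered here, and "the series" means these few. Any claim that something is new, unique, unknown or untested is made for them only; others in the source may bear on it.

Measured so far:
compound 1 `C=C1C[C@H](CO)OC1=O` — 27200 nM
compound 2 `C=C1C[C@H]([C@H](O)c2ccccc2)OC1=O` — 6900 nM; 8000 nM (2 entries)

In a functional assay on L1210 cells (Mus musculus) for cytotoxicity (a higher number here means a weaker inhibitor, a lower number a stronger inhibitor), compound 1 gives 27200 nM, the higher of the two numbers on hand; compound 2 gives 6900 nM; 8000 nM (2 entries), and its repeat entries the several entries of compound 2 in this assay, 6900 nM; 8000 nM (2 entries) agree with one another within the usual scatter. Among the measured compounds shown here, no pair of measured compounds differs in a single place, so no step size is known from the series itself. Compound 3 `C=C1C[C@H]([C@@H](C)O)OC1=O` differs from compound 1 by methyl in place of hydrogen on a saturated chain carbon bound to an oxygen on a saturated carbon and a saturated ring carbon. The change adds little. Compound 2 gives 6900 nM; 8000 nM (2 entries) and carries a far larger group than compound 1 on the same carbon. For compound 3 a modest gain in this assay is expected, the step of a 1.8-fold lower number from compound 1 to compound 3 (0.26 log units; within the scatter) lying at or only a little beyond the scatter. Compound 3 is estimated at 15000 nM, in the range 6000 nM to 40000 nM.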

Compound 3, half-maximal inhibitory concentration: 19300 nM
The estimate for compound 3 lay 1.3-fold (0.11 log units) below the measured number, within the range that was stated.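

In this assay, the first step read directly at this position is methyl in place of hydrogen on a saturated chain carbon bound to an oxygen on a saturated carbon and a saturated ring carbon, and it gives a 1.4-fold lower number from compound 1 to compound 3 (0.15 log units; within the scatter). Going from hydroxymethyl to 1-hydroxyethyl thus leaves this assay without a difference that can be told from the scatter, so this position tolerates methyl with no measurable penalty. The repeat entries show how closely two numbers can agree in this series: the several entries of compound 2 in this assay, 6900 nM; 8000 nM (2 entries)

From the compounds shown here alone, whether a longer chain such as propyl at this position gives a step beyond the scatter remains open. Also open, going by these compounds, is what an amine or a carboxylic acid on the same carbon would do to the number.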